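The source may report more compounds than this note shows. Statements on the series, on what has been measured and on what is new or still open speak of the compounds shown alone.

Values in a functional assay on A-431 cells (Homo sapiens) for cytotoxicity; on this read-out lower numbers stand for an effect already at smaller amounts and higher numbers for an effect only at larger amounts of compound:
- compound 1 `COC1=C(C)C(=O)/C(=C(O)/C=C/c2ccc(Br)cc2)C(=O)C1(C)C`: 9 ug/mL
- compound 2 `COC1=C(C)C(=O)/C(=C(O)/C=C/c2ccc(F)cc2)C(=O)C1(C)C`: 4.1 ug/mL
- compound 3 `COC1=C(C)C(=O)/C(=C(O)/C=C/c2c(C)cc(C)cc2C)C(=O)C1(C)C`: 20 ug/mL

In this assay, compound 2 at 4.1 ug/mL has the lowest number of the three. Compound 1 and compound 3 both carry a different aryl group and show higher numbers.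

Not yet measured is compound 4 `C=Cc1ccccc1/C=C/C(O)=C1/C(=O)C(C)=C(OC)C(C)(C)C1=O`, where 2-vinylphenyl stands in place of 4-fluorophenyl on a double-bonded chain carbon bound to a double-bonded chain carbon: 2-vinylphenyl in place of 4-fluorophenyl on a double-bonded chain carbon bound to a double-bonded chain carbon.

Going by the values given here, the only measured step, a 2.2-fold lower number from compound 1 to compound 2 (0.34 log units; beyond the scatter), is modest. It concerns fluoro in place of bromo on an aromatic carbon, so it bears on this change only loosely. Among the compounds with values here, no measured compound carries a vinyl group. Compound 3 at 20 ug/mL marks the upper end of the numbers seen so far for a changed aryl group.

A modest to moderate move towards a higher number is therefore expected, with the estimated step being a 2.2-fold higher number from compound 2 to compound 4 (0.34 log units; beyond the scatter). The estimate for compound 4 is 9 ug/mL, with an expected range of 3.5 ug/mL to 22 ug/mL.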

Compound 4, concentration for half-maximal effect: 2.6 ug/mL
Estimate against measurement, compound 4: 3.5-fold (0.54 log units) above; the whole stated range lies above it.
By their numbers in this assay, from the lowest: compounds 4 and 2 (each within the scatter of the next); then compound 1; then compound 3.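

In this assay, 2-vinylphenyl on a double-bonded chain carbon bound to a double-bonded chain carbon gives a 1.6-fold lower number from compound 2 to compound 4 (0.20 log units; within the scatter) and so cannot be told apart from 4-fluorophenyl at this place. Against 4-bromophenyl, the same group gives a 3.5-fold lower number from compound 1 to compound 4 (0.54 log units; beyond the scatter) and thus stands clear of the bromo compound, the first such step here for an aryl group without a halogen. This place therefore tolerates the exchange of a fluoro substituent for a vinyl group, with one double bond outside the aromatic ring, without the number rising beyond the scatter.

Open, as far as these compounds go, is how an aryl group bearing an amine or a carboxylic acid, or a longer chain in place of the vinyl group, would read in this assay at this place. No measurement shown here accounts for these numbers.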